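Chloro in place of fluoro on the shared core

The source may hold more compounds than are shown below. What is called first, only, known or untested is meant among the compounds shown, and "the series" means these compounds.

In a functional assay on DU-145 cells (Homo sapiens), read by sulforhodamine B assay, with a stated time of 5 days (a higher number here means a weaker inhibitor of growth, a lower number a stronger inhibitor of growth), compound 1 (`OC[C@H]1O[C@@H](n2cc(F)c3c(-c4ccccc4)ncnc32)[C@H](O)[C@@H]1O`) gives 580 nM as its value. Compound 2 (`OC[C@H]1O[C@@H](n2cc(F)c3c(-c4c[nH]cn4)ncnc32)[C@H](O)[C@@H]1O`) gives 890 nM there, and the two lie within the scatter of each other. The change from compound 1 to compound 3 (`OC[C@H]1O[C@@H](n2cc(Cl)c3c(-c4ccccc4)ncnc32)[C@H](O)[C@@H]1O`) is chloro in place of fluoro on an aromatic carbon and amounts to chloro in place of fluoro on an aromatic carbon. For the measured compounds named here, the one measured step (a 1.5-fold higher number from compound 1 to compound 2 (0.19 log units; within the scatter)) concerns the phenyl group and leaves the fluoro untouched, so no measurement speaks directly to this exchange of halogens. Without such evidence, no step beyond the scatter is expected in this assay and no direction can be favoured. The estimate means a 1.2-fold lower number from compound 1 to compound 3 (0.06 log units; within the scatter) as the expected step. For compound 3 the expected value is 500 nM with an estimated range from 130 nM to 1900 nM for now.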

Compound 3, concentration for 50% growth inhibition: 140 nM
For compound 3 the middle estimate is 3.6-fold (0.55 log units) above the measured one; low and high end bracket the measured number.
By their numbers in this assay, from the lowest: compound 3; then compounds 1 and 2 (each within the scatter of the next).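

In this assay, the halogen on the five-membered aromatic ring proves to be a sensitive point on the shared core: a 4.1-fold lower number from compound 1 to compound 3 (0.62 log units; beyond the scatter). Among the steps shown, this is the only one beyond the scatter, whereas a 1.5-fold higher number from compound 1 to compound 2 (0.19 log units; within the scatter). Thus a single atom exchange, two ring bonds from the ring nitrogen, changes the number more clearly than replacing the whole phenyl group did, although nothing given here accounts for this difference.

The compounds shown leave open whether bromo, iodo, methyl or nitrile at the same carbon would continue the change seen with chloro or reverse it. They also leave open whether chloro in place of fluoro would give a similar step with 1H-imidazol-4-yl in place of phenyl.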